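The source may hold more compounds than are shown below. What is called first, only, known or untested is meant among the compounds shown, and "the series" means these compounds.

In an assay on HEK293 cells for positive allosteric modulation of metabotropic glutamate receptor 2 (Rattus norvegicus), read by thallium flux, with a stated time of 2.5 min (a lower number here means a smaller maximal response, a higher number a larger maximal response), compound 1 `COc1ccc(C(=O)O)cc1OCCCCOc1ccc(C(=O)CC2CCCC2)c(O)c1C` gives 91.8%, while compound 2 `COc1ccc(C(=O)O)cc1OCCCCOc1ccc(C(C)=O)c(O)c1C` gives 70.7%. The two share one core and differ only by cyclopentyl in place of hydrogen on a saturated chain carbon bound to a carbonyl carbon, a change that produced a number 21.1 percentage points higher from compound 2 to compound 1 (beyond the scatter). Compound 3 `CC(=O)c1ccc(OCCCCOc2ccc(C(=O)O)cc2C)c(C)c1O` rests on a second core; how its core differs from that of compound 2 is not broken down here. In this assay compound 3 gives 83.1%, which lies within the scatter of the value of compound 1 and beyond the scatter above the value of compound 2.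

Compound 4 `Cc1cc(C(=O)O)ccc1OCCCCOc1ccc(C(=O)CC2CCCC2)c(O)c1C` is built on the core of compound 3 and carries the same change, (cyclopentyl in place of hydrogen on a saturated chain carbon bound to a carbonyl carbon), at the same place. Its response in this assay is therefore expected to rise, and the step is estimated as a number 10.9 percentage points higher from compound 3 to compound 4 (beyond the scatter) because a number 21.1 percentage points higher from compound 2 to compound 1 (beyond the scatter) was seen on the other core. The rise is expected to be smaller than that earlier step, since compound 3 already sits high and the read-out is a share of the maximal response. For compound 4 the expected value in this assay is 94%, within 80% to 108%.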

Compound 4, largest response reached (reported as percent of maximum), in percent of the reference or control that the assay uses: 84.6%
The estimate for compound 4 lay 9.4 percentage points above the measured number; the measured number falls inside the stated range.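

In this assay, the cyclopentyl change did not carry from one core to the other at the same size: the same change on two cores in this assay, a number 21.1 percentage points higher (beyond the scatter) from compound 2 to compound 1 and a number 1.5 percentage points higher (within the scatter) from compound 3 to compound 4, 19.6 percentage points apart, beyond the scatter of two such steps On the core of compound 3 the step reads a number 1.5 percentage points higher from compound 3 to compound 4 (within the scatter), so the gain seen on the core of compound 1 does not reappear there, and with cyclopentyl in place on both cores the step between them reads a number 7.2 percentage points lower from compound 1 to compound 4 (within the scatter). This rests on a single pair for each core, so it shows that the size of the step depends on the core in these compounds, but it does not show why the two steps differ or what the change would do on a further core.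

Still open, going by these compounds, is whether a cyclohexyl group or a straight butyl chain in place of cyclopentyl would also give steps that differ between the two cores. Also open, on these data alone, is how either core would respond with an amide or a tetrazole in place of the carboxylic acid.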